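Fluoro to trifluoromethyl on the aromatic ring

The compounds below may be only part of what the source reports. "The series", "measured", "known", "first", "only" and "open" are said of these compounds alone.

In an ADME assay on cells (Epithelial cell, Homo sapiens) for antiproliferative activity, read by MTT assay, with a stated time of 48 h (a lower number here means a stronger inhibitor, a higher number a weaker inhibitor), compound 3 `COC(=O)/C(=C/c1ccccc1)CN1C(=O)[C@@H](OC)[C@H]1c1cccc(F)c1` gives 38500 nM and lies within the scatter of compound 1 `COC(=O)/C(=C/c1ccccc1)CN1C(=O)[C@@H](OC)[C@H]1c1ccc(Cl)cc1Cl` at 70000 nM on this measure. Compound 2 `COC(=O)/C(=C/c1ccccc1)CN1C(=O)[C@@H](OC)[C@H]1c1ccc(OC)cc1` is recorded as "not toxic" (no number reported) with no number attached. Compound 4 `COC(=O)/C(=C/c1ccccc1)CN1C(=O)[C@@H](OC)[C@H]1c1cccc(C(F)(F)F)c1` has not been measured yet and differs from compound 3 in one place: trifluoromethyl in place of fluoro on an aromatic carbon with trifluoromethyl in place of fluoro on an aromatic carbon. Within the data shown here, the only measured step that bears on this is a 1.8-fold lower number from compound 1 to compound 3 (0.26 log units; within the scatter) and it exchanges a whole substituted phenyl group while staying within the scatter. No step beyond the scatter is therefore expected, in either direction. In this assay compound 4 is estimated at 36000 nM with 15000 nM to 85000 nM as its expected range.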

Compound 4, half-maximal inhibitory concentration: 71800 nM
Compound 4: the middle estimate sits 2.0-fold (0.30 log units) below what was measured; the measured number falls inside the stated range.
By their numbers in this assay, from the lowest: compounds 3, 1 and 4 (each within the scatter of the next).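

Putting trifluoromethyl, a group with more heavy atoms, in place of fluoro on this aromatic carbon gives a 1.9-fold higher number from compound 3 to compound 4 (0.27 log units; within the scatter) in this assay, so the numbers do not separate these two groups. Exchanging the whole aryl group gives a 1.0-fold higher number from compound 1 to compound 4 (0.01 log units; within the scatter), so 3-(trifluoromethyl)phenyl and 2,4-dichlorophenyl cannot be told apart here either. No measurement at hand explains these results.

Going by these compounds, whether an amine, a carboxylic acid or a longer alkyl chain on this aromatic carbon would shift the number beyond the scatter remains open.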